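Methyl Replaces Hydroxy on a Strong Nicotinic Receptor Binder

The compounds below may be only part of what the source reports. "The series", "measured", "known", "first", "only" and "open" are said of these compounds alone.

Compound 1 `Oc1ccc(Nc2cncc(N3CC4CC(C3)N4)c2)cc1` shows the lower of the two numbers measured here: in an assay on HEK293 cells for displacement of a labelled ligand from Neuronal acetylcholine receptor; alpha3/beta4 (Homo sapiens) (on this read-out lower numbers stand for stronger inhibition and higher numbers for weaker inhibition), compound 1 gives 0.988 nM, while compound 2 `Oc1ccc(Nc2ccc(N3CC4CC(C3)N4)cn2)cc1` gives 165 nM, a gap far beyond the usual scatter. Compound 3 `Cc1ccc(Nc2cncc(N3CC4CC(C3)N4)c2)cc1` differs from compound 1 by a single change, (methyl in place of hydroxy on an aromatic carbon). For the measured compounds named here, no measured pair shows this change, so its size is unknown. The number is nevertheless expected to rise, with an expected step of a 10-fold higher number from compound 1 to compound 3 (1.01 log units; beyond the scatter), beyond the scatter. Compound 3 is therefore estimated at 10 nM, in a range from 2 nM to 60 nM.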

Compound 3, inhibition constant: 1.4 nM
The estimate for compound 3 lay 7.1-fold (0.85 log units) above the measured number; measured number outside the range, below it.
By their numbers in this assay, from the lowest: compounds 1 and 3 (each within the scatter of the next); then compound 2.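

Going from 4-hydroxyphenyl to 4-methylphenyl gives a 1.4-fold higher number from compound 1 to compound 3 (0.15 log units; within the scatter), so compound 1 and compound 3 cannot be told apart on this read-out. At this position, then, methyl can stand in place of hydroxy, even though the hydrogen-bond donor and acceptor counted on hydroxy are absent from methyl. Nothing available explains why the two compounds match. Still open, as far as these compounds go, is how an amine, a methoxy group or a chlorine atom would fare at this place. From the compounds shown here alone, whether methyl would behave the same way on the core of compound 2 is also open.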